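This account rests on a few compounds, and the source may have more. Where it says the series, first, only, none or still open, it means among the compounds named here.

Of the compounds shown here, three have so far been tested in an ADME assay on liver for metabolic stability, with Liver microsome (Homo sapiens) as the target, read by LC-MS, using microsomes; a lower number here means slower removal, a higher number faster removal of the compound. Compound 1 `O=C(NCc1cc(Cl)ccc1-n1cnnn1)[C@@H]1C[C@@H]2C[C@@H]2N1C(=O)[C@H](O)CC1CC1` reads < 12 mL.min-1.g-1, which is a limit of the assay and not a number. Compound 3 `CC(C)(C)[C@@H](O)C(=O)N1CS(=O)(=O)C[C@H]1C(=O)NCc1cc(Cl)ccc1-n1cnnn1` reads < 12 mL.min-1.g-1, which is also a limit. Among the compounds with values here, compound 2 `COC(C)(C)[C@@H](O)C(=O)N1C[C@H]2C[C@H]2[C@H]1C(=O)NCc1cc(Cl)ccc1-n1cnnn1` gives 23 mL.min-1.g-1, the only reading of the three that is an actual number. The data therefore offer one firm point, together with the limit of < 12 mL.min-1.g-1 in this assay, at which 2 of the 3 values shown sit.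

Compound 4 `CC1(C[C@@H](O)C(=O)N2C[C@H]3C[C@H]3[C@H]2C(=O)NCc2cc(Cl)ccc2-n2cnnn2)CC1` has not yet been measured. It differs from compound 2 in one place: (1-methylcyclopropyl)methyl in place of 1-methoxy-1-methylethyl on a saturated chain carbon bound to a carbonyl carbon and an oxygen on a saturated carbon. Put plainly, (1-methylcyclopropyl)methyl stands in place of 1-methoxy-1-methylethyl on a saturated chain carbon bound to a carbonyl carbon and an oxygen on a saturated carbon. The two groups have the same number of heavy atoms, but the new one has a ring and no oxygen.

Within the data shown here, no pair of measured compounds shows what a swap of this kind does in this assay. The expectation is therefore modest: no step beyond the usual scatter, and no firm direction. The estimated move a 1.0-fold lower number from compound 2 to compound 4 (0.02 log units; within the scatter) is expected to be small. Compound 4 is expected to give 22 mL.min-1.g-1, with an estimated range of 12 mL.min-1.g-1 to 45 mL.min-1.g-1.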

Compound 4, intrinsic clearance in microsomes: 12 mL.min-1.g-1
Compound 4: middle estimate off by 1.8-fold (0.26 log units), on the high side; the range from low to high includes it.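

Within the data shown here, this is the first pair of measured compounds that differ in one place, and in this assay putting (1-methylcyclopropyl)methyl in place of 1-methoxy-1-methylethyl gives a 1.9-fold lower number from compound 2 to compound 4 (0.28 log units; within the scatter). At this saturated chain carbon, bound to a carbonyl carbon and an oxygen on a saturated carbon, giving up the hydrogen-bond acceptor and taking on a three-membered ring, with the heavy-atom count unchanged, therefore does not separate the two compounds in this read-out. Any reading of further changes here needs care, because the scale of this assay ends in a limit and not a number: the limit of < 12 mL.min-1.g-1 in this assay, at which 2 of the 4 values shown sit.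

Among these compounds, the one pair changes the oxygen and the ring together, so what each of the two does alone remains unknown. It also leaves open how very different groups at the same place, such as an amine, a carboxylic acid or a longer chain, would read in this assay.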